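This account rests on a few compounds, and the source may have more. Where it says the series, first, only, none or still open, it means among the compounds named here.

Compound 1 `C[C@@H](C(=O)O)c1nn(Cc2cn3cc(OCC4CC4)c(Cl)cc3n2)c2ccccc2c1=O` carries a 1-carboxyethyl group on the shared core. In a functional assay on HFL1 cells for antagonist activity at sphingosine 1-phosphate receptor 2 (Homo sapiens), read by ELISA, with a stated time of 24 h, in the presence of a further agent that is not named here (on this read-out higher numbers stand for weaker inhibition and lower numbers for stronger inhibition), compound 1 gives 3180 nM, the highest number among the three compounds measured. Compound 2 `O=C(O)Cn1nc(Cc2cn3cc(OCC4CC4)c(Cl)cc3n2)c2ccccc2c1=O` gives 275 nM in this assay, and compound 3 `O=C(O)Cn1nc(Cn2cc3cc(OCC4CC4)c(Cl)cc3n2)c2ccccc2c1=O` gives 647 nM; both gaps to compound 1 lie beyond the usual scatter, so compound 1 is the weakest inhibitor of the three. Among the compounds with values here, compounds 2 and 3 differ from compound 1 in more than one place, so no single-change step toward compound 1 can be drawn from them.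

Compound 4 `O=C(O)C1(c2nn(Cc3cn4cc(OCC5CC5)c(Cl)cc4n3)c3ccccc3c2=O)CC1` is compound 1 with one change: 1-carboxycyclopropyl in place of 1-carboxyethyl on an aromatic carbon. Within the data shown here, nothing measured here isolates the effect of closing the 1-carboxyethyl into a 1-carboxycyclopropyl; the only guide is that compound 1 with its 1-carboxyethyl group gives 3180 nM. The step from compound 1 to compound 4 is therefore expected to be small, possibly a modest move toward stronger inhibition but quite possibly none beyond the scatter, as a 1.6-fold lower number from compound 1 to compound 4 (0.20 log units; within the scatter) expresses. Compound 4 is estimated to give 2000 nM in this assay, with a plausible range from 600 nM to 7000 nM.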

Compound 4, half-maximal inhibitory concentration: 304 nM
Compound 4: the middle estimate sits 6.6-fold (0.82 log units) above what was measured, and the stated range ends above it.
By their numbers in this assay, from the lowest: compounds 2 and 4 (each within the scatter of the next); then compound 3; then compound 1.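

The change of 1-carboxyethyl to 1-carboxycyclopropyl, on an aromatic carbon next to the ring nitrogen, gives a 10-fold lower number from compound 1 to compound 4 (1.02 log units; beyond the scatter) in this assay, a large step and the first single-change step available in this set, showing that the read-out is highly sensitive to the group at this place. The two groups have the same counts of hydrogen-bond donors and acceptors and neither has a net charge, so the step accompanies the gain of a three-membered carbon ring and the loss of the defined stereocentre, and these two features cannot be separated here. No measured evidence accounts for the size of this step.

The compounds shown leave open whether the step belongs to the ring or to the stereocentre, a question that the mirror-image form of compound 1 or a 2-carboxypropan-2-yl group at this place would address. They also leave open how a larger 1-carboxycyclobutyl group would read, and whether an amide or a tetrazole could stand in place of the carboxylic acid on the cyclopropane of compound 4.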